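Swapping the Carbamate for a Nitrophenyl Group on the Piperazine

The compounds below may be only part of what the source reports. "The series", "measured", "known", "first", "only" and "open" are said of these compounds alone.

Of the compounds shown here, three sharing one core have been tested in a functional assay on SK-N-SH cells (Homo sapiens) for inhibition, read by MTT assay; on this read-out lower numbers stand for stronger inhibition and higher numbers for weaker inhibition. Compound 3 `CC(C)(C)OC(=O)N1CCN(CC(=O)Nc2ccc(C(=O)/C=C/c3cn(Cc4ccc(Br)cc4)nn3)cc2)CC1` gives 25800 nM, the lowest of the three numbers; compound 1 `COc1ccccc1N1CCN(CC(=O)Nc2ccc(C(=O)/C=C/c3cn(Cc4ccc(Br)cc4)nn3)cc2)CC1` gives 28000 nM, and a 1.1-fold lower number from compound 1 to compound 3 (0.04 log units; within the scatter). Compound 2 `O=C(CN1CCN(c2ccccc2)CC1)Nc1ccc(C(=O)/C=C/c2cn(Cc3ccc(Br)cc3)nn2)cc1` gives 72400 nM, and a 2.8-fold lower number from compound 2 to compound 3 (0.45 log units; beyond the scatter). Compound 4 `O=C(CN1CCN(c2ccc([N+](=O)[O-])cc2)CC1)Nc1ccc(C(=O)/C=C/c2cn(Cc3ccc(Br)cc3)nn2)cc1` carries 4-nitrophenyl in place of tert-butoxycarbonyl on an amine nitrogen in a ring. The step from compound 3 to compound 4 reverses the direction of the steps into compound 3: one aryl-for-carbamate exchange stayed within the scatter, the other was modest, and a 2.6-fold higher number from compound 1 to compound 2 (0.41 log units; beyond the scatter) shows the aryl substituent can matter. A modest rise is therefore expected in this assay, a 1.7-fold higher number from compound 3 to compound 4 (0.24 log units; within the scatter). Compound 4 is estimated at 45000 nM, with a range from 20000 nM to 110000 nM.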

Compound 4, half-maximal inhibitory concentration: 26500 nM
Compound 4: middle estimate off by 1.7-fold (0.23 log units), on the high side, and the stated range covers the measured number.
By their numbers in this assay, from the lowest: compounds 3, 4 and 1 (each within the scatter of the next); then compound 2.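

In this assay, 4-nitrophenyl on the ring amine nitrogen matches tert-butoxycarbonyl, a 1.0-fold higher number from compound 3 to compound 4 (0.01 log units; within the scatter), so an aryl group here need not carry the penalty seen with plain phenyl. Nitro in place of hydrogen on the aromatic carbon recovers that loss, a 2.7-fold lower number from compound 2 to compound 4 (0.44 log units; beyond the scatter), while the two substituted aryl groups cannot be told apart, a 1.1-fold lower number from compound 1 to compound 4 (0.02 log units; within the scatter). No supporting data explain why either substituent has this effect. On these data alone, it remains open whether an amine or a carboxylic acid on that aryl ring would give the same result as nitro and methoxy.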